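Three amides at the tolerance limit and a nitrile analogue

The source may hold more compounds than are shown below. What is called first, only, known or untested is meant among the compounds shown, and "the series" means these compounds.

The study measures tolerance in a toxicity assay on THP-1 cells (Homo sapiens) for inhibition (a higher number here means that more compound is tolerated, a lower number that less compound is tolerated), across a small set of amides that share one core. Compound 1 `COc1ccc(-c2cnc(NC(=O)c3ccccc3F)n2C)cc1` gives in this assay only a limit, > 100000 nM. Compound 2 `COc1ccc(-c2cnc(NC(=O)c3ccco3)n2C)cc1` likewise reaches only a limit in this assay, > 100000 nM. Compound 3 `COc1ccc(-c2cnc(NC(=O)c3ccccc3OC)n2C)cc1` also stands at a limit in this assay, > 100000 nM. With all three results at the same limit, compound 3 stands level with the other two, and none of the three can be placed above or below another.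

The steps among the measured compounds are therefore unreadable: a step that the two limits leave unreadable from compound 1 to compound 2, a step that the two limits leave unreadable from compound 1 to compound 3 and a step that the two limits leave unreadable from compound 2 to compound 3. The one fact that holds across the set is the limit of > 100000 nM in this assay, at which 3 of the 3 values shown sit.

Compound 4 `COc1ccc(-c2cnc(NC(=O)c3cccc(C#N)c3)n2C)cc1` has not yet been measured. It differs from compound 3 by 3-cyanophenyl in place of 2-methoxyphenyl on a carbonyl carbon. Going by the values given here, the steps that bear on this change all sit at the limit, so their size is unknown, and no step beyond the scatter can be read from them. Compound 4 is accordingly expected to sit at or near the same limit, with an estimated value of 150000 nM in this assay, in a range from 50000 nM to 500000 nM. The step this estimate implies is a step that the limit leaves unreadable from compound 3 to compound 4, expected to be no real change.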

Compound 4, half-maximal cytotoxic concentration: > 100000 nM
Compound 4 was reported as a limit (the forecaster's own chance of this, stated with the estimate: 85%); the middle value does not contradict the limit.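

Compound 4 also gives only a limit in this assay, so its steps from compound 1, compound 2 and compound 3 cannot be read. The one shared result across the set is: the limit of > 100000 nM in this assay, at which 4 of the 4 values shown sit.

The compounds shown leave open how far tolerance extends past that limit for any of the four amides, and whether any group on the carbonyl carbon changes it.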